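The source may hold more compounds than are shown below. What is called first, only, known or untested is meant among the compounds shown, and "the series" means these compounds.

Compound 1 `Cc1ncnc2c1c(-c1cc3ccccc3o1)cn2[C@@H]1O[C@H](CO)[C@@H](O)[C@H]1O` gives in a functional assay on HepG2 cells (Homo sapiens) for antiproliferative activity, read by XTT assay, with a stated time of 72 h (on this read-out lower numbers stand for stronger inhibition and higher numbers for weaker inhibition), only a limit of the assay, > 20000 nM.
Compound 2 `Nc1nc2c(c(-c3ccco3)cn2[C@@H]2O[C@H](CO)[C@@H](O)[C@H]2O)c(=O)[nH]1` likewise gives only a limit, > 20000 nM.
Compound 3 `CN(C)c1ncnc2c1c(-c1ccoc1)cn2[C@@H]1O[C@H](CO)[C@@H](O)[C@H]1O` gives 12500 nM.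

Compound 2 therefore stands at the limit of the assay rather than at a number, and it shares that position with compound 1, since (the limit of > 20000 nM in this assay, at which 2 of the 3 values shown sit). Compound 4 `Nc1nc2c(c(-c3ccoc3)cn2[C@@H]2O[C@H](CO)[C@@H](O)[C@H]2O)c(=O)[nH]1` is built from the same atoms as compound 2, joined differently: furan-3-yl in place of furan-2-yl on an aromatic carbon. Among the measured compounds shown here, no measured pair shows this change alone, so its size is not known from the data. Compound 3 carries furan-3-yl on another core and sits at the weak end of the assay. The step that the limit leaves unreadable from compound 2 to compound 4 is expected to be none beyond the scatter, with the estimate for compound 4 at 25000 nM, within 8000 nM to 80000 nM.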

Compound 4, half-maximal inhibitory concentration: > 20000 nM
Compound 4: a limit, no number; the forecaster's own chance of this, stated with the estimate: 80%; the middle value lies beyond the limit too.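

Compound 2 and compound 4 both give only a limit, so the step between them cannot be read: the limit of > 20000 nM in this assay, at which 3 of the 4 values shown sit.

The compounds shown leave open whether furan-3-yl in place of furan-2-yl on an aromatic carbon changes the result in this assay at all.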